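The source may report more compounds than this note shows. Statements on the series, on what has been measured and on what is new or still open speak of the compounds shown alone.

Working notes on the series. In a physicochemical assay for lipophilicity, using the shake flask method, at pH 7.4 (a higher number here means a more lipophilic compound, a lower number a more polar compound), compound 1 `CCCC(Oc1ccc(-n2cc(OC)cn2)cc1)c1ccc(C(=O)NCCC(=O)O)cc1` gives 1.4, while compound 2 `CCCC(Oc1ccc(-n2cc(C(=O)N(C)C)cn2)cc1)c1ccc(C(=O)NCCC(=O)O)cc1` gives 0.5, the lower of the two numbers. Compound 3 `CCCC(Oc1ccc(-n2cc(C(F)(F)F)c(C)n2)cc1)c1ccc(C(=O)NCCC(=O)O)cc1` has 3-methyl-4-(trifluoromethyl)-1H-pyrazol-1-yl in place of 4-(dimethylcarbamoyl)-1H-pyrazol-1-yl on an aromatic carbon. For the measured compounds named here, one measured step bears on this change: a number 0.90 log units lower from compound 1 to compound 2 (beyond the scatter), a modest move beyond the scatter, with dimethylcarbamoyl in place of methoxy on an aromatic carbon. Here dimethylcarbamoyl leaves, so a rise in this assay is expected, reversing the direction of that step. Going by the values given here, no measured compound carries the entering group, which leaves the size a matter of judgement. The expected step, somewhat larger than the measured one and beyond the scatter, is a number 1.80 log units higher from compound 2 to compound 3 (beyond the scatter). The estimate for compound 3 is 2.3, with an expected range from 1.7 to 2.9.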

Compound 3, distribution coefficient: 2.8
Compound 3: the middle estimate sits 0.50 log units below what was measured, and the stated range covers the measured number.
By their numbers in this assay, from the lowest: compound 2; then compound 1; then compound 3.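

For the compounds shown here, at this position, on an aromatic carbon para to a large group, this assay shows a wider span than the earlier pair did: a number 2.30 log units higher from compound 2 to compound 3 (beyond the scatter), and a number 1.40 log units higher from compound 1 to compound 3 (beyond the scatter), both large, where the only earlier step was modest. The larger step comes with no change in heavy-atom count, as the leaving and entering groups have the same number of heavy atoms, so that count alone does not set the read-out across this pair. No measurement at hand accounts for the size of either step.

The entering group differs in more than one feature, so the compounds shown do not divide the rise between the methyl and the trifluoromethyl. Going by these compounds alone, a pyrazole carrying only one of these two groups, or an amine or a nitrile in their place, would show how far the read-out depends on each.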